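Chloro for fluoro at the ring-nitrogen-flanked position

A few compounds are considered here, and "the series" means these few. Any claim that something is new, unique, unknown or untested is made for them only; others in the source may bear on it.

Three measured compounds share one core. Compound 1 `COc1cccc(Cn2cnc3sc(-c4ccncc4)cc3c2=O)c1` carries pyridin-4-yl and in an assay on isolated protein for inhibition of Rho-associated protein kinase 2 (Homo sapiens), read by radiometric assay and 33P incorporation, with a stated time of 40 min, in the presence of a further agent that is not named here (a lower number here means a stronger inhibitor, a higher number a weaker inhibitor), compound 1 gives 6 nM. Compound 2 `COc1cccc(Cn2cnc3sc(-c4cccnc4)cc3c2=O)c1` carries pyridin-3-yl and gives 3480 nM; the step is a 580-fold higher number from compound 1 to compound 2 (2.76 log units; beyond the scatter). Compound 3 `COc1cccc(Cn2cnc3sc(-c4ccnc(F)c4)cc3c2=O)c1` gives 83 nM, the second highest of the three numbers; it stands at a 14-fold higher number from compound 1 to compound 3 (1.14 log units; beyond the scatter) and at a 42-fold lower number from compound 2 to compound 3 (1.62 log units; beyond the scatter).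

Compound 4 `COc1cccc(Cn2cnc3sc(-c4ccnc(Cl)c4)cc3c2=O)c1` differs from compound 3 by chloro in place of fluoro on an aromatic carbon. For the measured compounds named here, no measured step swaps one halogen for another. The only step touching this carbon is a 14-fold higher number from compound 1 to compound 3 (1.14 log units; beyond the scatter), where a halogen entering raised the number; whether a larger halogen moves further the same way or back is not shown. The step expected is a 1.8-fold higher number from compound 3 to compound 4 (0.26 log units; within the scatter), direction uncertain, the weaker side slightly favoured given a 14-fold higher number from compound 1 to compound 3 (1.14 log units; beyond the scatter). Compound 4 is therefore estimated at 150 nM in this assay, with a range from 40 nM to 600 nM.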

Compound 4, half-maximal inhibitory concentration: 501 nM
Compound 4: the middle estimate sits 3.3-fold (0.52 log units) below what was measured; the range from low to high includes it.
By their numbers in this assay, from the lowest: compound 1; then compound 3; then compound 4; then compound 2.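

At this carbon next to the ring nitrogen, the choice of halogen matters in this assay: there is a 6.0-fold higher number from compound 3 to compound 4 (0.78 log units; beyond the scatter) and, against the unsubstituted pyridin-4-yl, an 84-fold higher number from compound 1 to compound 4 (1.92 log units; beyond the scatter) as the cost of chloro, so the three compounds fall in the order hydrogen, fluoro, chloro. The chloro compound still keeps part of the edge over the pyridin-3-yl isomer, with a 6.9-fold lower number from compound 2 to compound 4 (0.84 log units; beyond the scatter) in this comparison. No measurement shown here accounts for this order.

From the compounds shown here alone, whether a non-halogen group at this carbon, such as methyl, methoxy or an amine, would come closer to compound 1 remains open. Also unanswered is whether the order hydrogen, fluoro, chloro would hold with changes elsewhere on the shared core.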